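Clearance notes on a propyl-to-ethyl side-chain pair

A few compounds are considered here, and "the series" means these few. Any claim that something is new, unique, unknown or untested is made for them only; others in the source may bear on it.

Measured so far:
compound 1 `CC[C@H](c1ccc(C(=O)O)c(Oc2cccc(Cl)c2)c1OC)N1CCC[C@H](n2cc(C)c(=O)[nH]c2=O)C1`: 84 mL/min/kg
compound 2 `CCC[C@@H](c1ccc(C(=O)O)c(Oc2cccc(Cl)c2)c1OC)N1CCC[C@H](n2cc(C)c(=O)[nH]c2=O)C1`: "not determined" (no result reported)

Compound 2 stands without a number: in an ADME assay on the whole organism (strain Wistar) for pharmacokinetics, with Rattus norvegicus as the target, given by the intravenous route (a lower number here means slower removal, a higher number faster removal of the compound), compound 2 is recorded only as "not determined" (no result reported), so its position in the series cannot be fixed. Within the data shown here, the one anchor is compound 1, which in this assay gives 84 mL/min/kg, a fast removal.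

Compound 3 `CC[C@@H](c1ccc(C(=O)O)c(Oc2cccc(Cl)c2)c1OC)N1CCC[C@H](n2cc(C)c(=O)[nH]c2=O)C1` is the next compound to be tested. It differs from compound 2 by hydrogen in place of methyl on a saturated chain carbon, three bonds along the chain from an amine nitrogen in a ring and an aromatic carbon. With no number for compound 2, the step itself cannot be read, and the expectation is for no change beyond the usual scatter in this assay on this single change.

Resting on compound 1 as the only measured point in this assay, compound 3 is expected to be cleared at about 70 mL/min/kg, with a range of 30 mL/min/kg to 140 mL/min/kg.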

Compound 3, clearance: 73 mL/min/kg
Compound 3: the middle estimate sits 1.0-fold (0.02 log units) below what was measured; the measured number falls inside the stated range.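

The configuration at this position makes no reading difference in this assay: a 1.2-fold lower number from compound 1 to compound 3 (0.06 log units; within the scatter). The stereocentre at the saturated chain carbon is drawn R in compound 1 and S in compound 3, and the comparison rests on a clean single difference: the fact that compounds 1 and 3 differ only in the configuration as drawn With the ethyl group in place, rapid removal therefore holds for both drawn configurations at this carbon, and compound 3 gives 73 mL/min/kg.

As far as these compounds go, compound 2 has no number, so the change from propyl to ethyl cannot be read, and the effect of chain length at this carbon remains unknown. Also open, from the compounds shown here alone, is how this assay would read with a cyclopropyl group or a butyl chain on this carbon, or with the opposite configuration at the second stereocentre.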